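Adding a Second Benzyl Group to Compound 2

The compounds below may be only part of what the source reports. "The series", "measured", "known", "first", "only" and "open" are said of these compounds alone.

Compound 1 `Cc1cc(O)n2cc(-c3ccc([N+](=O)[O-])cc3)nc2n1`: in an ADME assay on cells (Fibroblast, Homo sapiens) for antiproliferative activity, read by MTT assay, with a stated time of 72 h (a lower number here means a stronger inhibitor of growth, a higher number a weaker inhibitor of growth), compound 1 gives > 100000 nM, which is a limit of the assay rather than a number.
Compound 2 `Cc1ccn2cc(-c3ccc(NCc4ccccc4)cc3)nc2c1`: in this assay compound 2 gives > 100000 nM, also a limit rather than a number.

Compound 2 therefore stands at the limit, where both values shown sit (the limit of > 100000 nM in this assay, at which 2 of the 2 values shown sit). Compound 3 `Cc1ccn2cc(-c3ccc(N(Cc4ccccc4)Cc4ccccc4)cc3)nc2c1` differs from compound 2 by benzyl in place of hydrogen on a nitrogen on an aromatic ring. Among the compounds with values here, no measured pair traces this change, so its size is unknown; the expectation is no shift beyond the scatter in this assay. Compound 3 is expected to give 100000 nM, estimated between 30000 nM and 300000 nM. The expected step is a number no higher from compound 2 to compound 3 (the limit leaves the size open).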

Compound 3, concentration for 50% growth inhibition: 52300 nM
Compound 3: middle estimate off by 1.9-fold (0.28 log units), on the high side; the range from low to high includes it.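

Putting benzyl in place of hydrogen on the nitrogen gives, in this assay, an at least 1.9-fold lower number from compound 2 to compound 3 (0.28 log units; that floor lies within the scatter). As far as these compounds go, compound 2 stands at a limit, so the true size of this step stays unknown, and the printed floor alone does not show a real gain. The change does bring this series its first value that is a number rather than a limit: the limit of > 100000 nM in this assay, at which 2 of the 3 values shown sit.

From the compounds shown here alone, it remains open how a methyl group or a longer chain such as phenethyl on this nitrogen would read. Going by these compounds, whether an amide at this nitrogen would give a number is equally open.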